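The source may report more compounds than this note shows. Statements on the series, on what has been measured and on what is new or still open speak of the compounds shown alone.

Measured so far:
compound 1 `COc1ccc(-c2c(-c3cc(OC)c(OC)c(OC)c3)c(=O)c2=O)cc1F`, 13 nM
compound 2 `COc1cc(-c2c(-c3ccc4[nH]ccc4c3)c(=O)c2=O)cc(OC)c1OC`, 1500 nM

Among the measured compounds shown here, of the two compounds measured in a functional assay on Bel-7402 cells (Homo sapiens) for inhibition, read by MTT assay, with a stated time of 72 h (a higher number here means a weaker inhibitor, a lower number a stronger inhibitor), compound 2 gives the higher number, 1500 nM, and so is the weaker inhibitor of the pair; the one step available, a 120-fold higher number from compound 1 to compound 2 (2.06 log units; beyond the scatter), shows how far it lies from compound 1. Compound 3 `COc1cc(-c2c(-c3ccc4cc[nH]c4c3)c(=O)c2=O)cc(OC)c1OC` keeps the shared core and changes only the point where the indole is attached: 1H-indol-6-yl in place of 1H-indol-5-yl on an aromatic carbon. For the measured compounds named here, no measured step shows what such a shift within the indole does here. Going by the values given here, the only step known, from compound 1 to compound 2, exchanged a quite different group and was large, but it does not speak to swapping one indolyl isomer for another. With nothing to lean on, the expectation is that compound 3 stays close to compound 2, giving no change at the digits printed from compound 2 to compound 3 (within the scatter), a step not expected to exceed the scatter. Compound 3 is therefore estimated at 1500 nM, with a range from 300 nM to 7000 nM.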

Compound 3, half-maximal inhibitory concentration: 3620 nM
Compound 3: the middle estimate sits 2.4-fold (0.38 log units) below what was measured; measured number inside the range.
By their numbers in this assay, from the lowest: compound 1; then compound 2; then compound 3.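

Moving the attachment point within the indole changes the result in this assay: with the same atoms joined differently, there is a 2.4-fold higher number from compound 2 to compound 3 (0.38 log units; beyond the scatter), so 1H-indol-5-yl and 1H-indol-6-yl do not behave as equals at this position, although the step is only modest. Replacing 3-fluoro-4-methoxyphenyl with the second indole isomer gives a 280-fold higher number from compound 1 to compound 3 (2.44 log units; beyond the scatter), so in these compounds the choice between that phenyl group and an indole counts for far more than the choice between the two indole isomers. Nothing measured here accounts for either difference.

The compounds shown leave open whether an indole carrying a methyl group on its ring nitrogen would behave like either isomer. They also leave open whether an aminophenyl group at this position would come closer to compound 1 than the indoles do.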